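Antiproliferative series: difluorophenyl in place of dimethoxyphenyl

This account rests on a few compounds, and the source may have more. Where it says the series, first, only, none or still open, it means among the compounds named here.

Measured in a functional assay on PC-3 cells (Homo sapiens) for antiproliferative activity, read by MTT assay, tested at 1 uM; a higher number here means a stronger effect of the compound at the concentration tested, a lower number a weaker effect:
compound 1 `COc1cc(C2=NN(C(C)=O)C(c3cccc(OC)c3OC)O2)cc(OC)c1OC` gives 35%
compound 2 `COc1cc(C(=O)N/N=C/c2ccc(Cl)c(Cl)c2)cc(OC)c1OC` gives 13.5%

Among the compounds with values here, compound 1 stands highest of the two numbers so far; the nearest is compound 2, whose reading is lower by a gap beyond the usual scatter. The two share the trimethoxyphenyl part but differ in the rest of the structure, so the values say nothing about any single change.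

Compound 3 `COc1cc(C2=NN(C(C)=O)C(c3ccc(F)c(F)c3)O2)cc(OC)c1OC` is not yet measured. It differs from compound 1 in one place: 3,4-difluorophenyl in place of 2,3-dimethoxyphenyl on a saturated ring carbon.

Within the data shown here, no step between measured compounds covers this kind of change, so its size in this assay is open. The expectation is a modest drop, not beyond the scatter, rather than a large loss. For compound 3 the estimated inhibition is 28%, in the range 10% to 48%. This estimate means an expected step of a number 7 percentage points lower from compound 1 to compound 3 (within the scatter), within the scatter.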

Compound 3, a percentage reported as inhibition, at one concentration (the size of the read-out at that concentration, not a potency): 35.5%
Beside the measured number, compound 3's estimate is 7.5 percentage points below it, and the stated range covers the measured number.
By their numbers in this assay, from the lowest: compound 2; then compounds 1 and 3 (each within the scatter of the next).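

In this assay, 3,4-difluorophenyl in place of 2,3-dimethoxyphenyl on the saturated ring carbon gives a number 0.5 percentage points higher from compound 1 to compound 3 (within the scatter) at the concentration tested. Within the data shown here, this is the first one-place comparison, and it shows that this position accepts the exchange of a dimethoxy-substituted aryl group for a difluoro-substituted one without a reading change beyond the scatter, even though the two hydrogen-bond acceptors of the leaving group are absent from the entering group. No available measurement bears on what lies behind this result.

Still open, from the compounds shown here alone, is how an unsubstituted phenyl, a morpholine or a carboxylic acid would read on this ring carbon. Also open, going by these compounds, is whether the acetyl group on the neighbouring ring atom can give way to a longer acyl chain on either aryl variant.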